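Metabolic stability of the carboxylate ester series in buffer

This account rests on a few compounds, and the source may have more. Where it says the series, first, only, none or still open, it means among the compounds named here.

Compound 1 `CC(C)C(=O)OCOC(=O)C1=C(S[C@@H]2CN[C@H](C(=O)Nc3cccc(C(=O)O)c3)C2)[C@H](C)[C@@H]2[C@@H]([C@@H](C)O)C(=O)N12` is the reference point of the series. In a physicochemical assay for metabolic stability, read by LC-MS, in phosphate buffer, with a stated time of 3 h, at pH 7.4, tested at 50 uM (on this read-out higher numbers stand for a more stable compound and lower numbers for a less stable compound), compound 1 reaches the limit of the assay at > 95%. Compound 2 `CC(C)C(=O)OCOC(=O)C1=C(S[C@@H]2CN[C@H](C(=O)Nc3cccc(C(=O)OCOC(=O)C(C)C)c3)C2)[C@H](C)[C@@H]2[C@@H]([C@@H](C)O)C(=O)N12` carries the same group on both acid positions; in this assay compound 2 sits at the limit of the assay with > 95%. Compound 3 `CC(C)c1oc(=O)oc1COC(=O)C1=C(S[C@@H]2CN[C@H](C(=O)Nc3cccc(C(=O)OCc4oc(=O)oc4C(C)C)c3)C2)[C@H](C)[C@@H]2[C@@H]([C@@H](C)O)C(=O)N12` is the cyclic variant; in this assay compound 3 likewise sits at the limit of the assay with > 95%. The step that the two limits leave unreadable from compound 1 to compound 2 cannot be read, since both ends lie at the limit, and the whole picture is summed up by the limit of > 95% in this assay, at which 3 of the 3 values shown sit.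

Compound 4 `CC(C)OC(=O)C1=C(S[C@@H]2CN[C@H](C(=O)Nc3cccc(C(=O)O)c3)C2)[C@H](C)[C@@H]2[C@@H]([C@@H](C)O)C(=O)N12` differs from compound 1 in one place: isopropyl in place of ((isopropylcarbonyl)oxy)methyl on an oxygen next to a carbonyl group. Within the data shown here, no measured step covers this change; the only step in hand, from compound 1 to compound 2, leaves its size unreadable. With every measured compound at the limit, no direction can be derived, and the change from compound 1 to compound 4 is expected to give no step beyond the scatter, expected as a step that the limit leaves unreadable from compound 1 to compound 4. For compound 4 in this assay the expected value is 96%, with a range from 88% to 100%, and most likely again a limit.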

Compound 4, percent of the compound remaining: > 95%
Compound 4: only a limit was reported; the forecaster's own chance of this, stated with the estimate: 80%; the middle value is on the limit's open side.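

In this assay compound 4 gives > 95%, which is a limit and not a number. No step can be read from compound 1 to compound 4, since the whole set stays at one limit: the limit of > 95% in this assay, at which 4 of the 4 values shown sit.

The compounds shown leave open whether any change of group at this place brings the percent remaining off the limit.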